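A few compounds are considered here, and "the series" means these few. Any claim that something is new, unique, unknown or untested is made for them only; others in the source may bear on it.

Compound 1 `CN1CCN(c2ccc(Nc3ncc4nc(Nc5ccc(F)cc5)n([C@H]5CCCN(S(=O)(=O)C6CC6)C5)c4n3)cc2)CC1`: 8.6 nM
Compound 2 `CN1CCN(c2ccc(Nc3ncc4nc(Nc5ccccc5)n([C@H]5CCN(C(=O)OC(C)(C)C)C5)c4n3)cc2)CC1`: 110 nM
Compound 3 `CC(=O)N1CC[C@H](n2c(Nc3ccccc3)nc3cnc(Nc4ccc(N5CCN(C)CC5)cc4)nc32)C1`: 260 nM

In a functional assay on HCC827 cells (Homo sapiens) for antiproliferative activity, read by MTT assay, with a stated time of 72 h (a lower number here means a stronger inhibitor, a higher number a weaker inhibitor), compound 1 stands at the lowest of the three numbers. The nearest of the others is compound 2 at 110 nM and the furthest compound 3 at 260 nM, both well beyond the scatter from compound 1. Within the data shown here, the one measured step in the set is a 2.4-fold higher number from compound 2 to compound 3 (0.37 log units; beyond the scatter), a modest shift. That step changes the group attached to the saturated ring nitrogen.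

Compound 4 `CN1CCN(c2ccc(Nc3ncc4nc(Nc5ccc(F)cc5)n([C@@H]5CCCN(C(=O)CO)C5)c4n3)cc2)CC1` differs from compound 1 by 1-((hydroxymethyl)carbonyl)piperidin-3-yl in place of 1-(cyclopropylsulfonyl)piperidin-3-yl on an aromatic nitrogen. Among the measured compounds shown here, no measured pair in this set exchanges a sulfonyl group for a carbonyl-bearing group at that position, so the only guide is the step from compound 2 to compound 3, which touched the same ring nitrogen substituent and moved the number only modestly. The exchange here is larger in kind than that one, so a somewhat larger step is expected, with the number for compound 4 drifting upward rather than downward. The estimate for compound 4 in this assay is 25 nM, with a range from 8 nM to 80 nM, meaning an expected step of a 2.9-fold higher number from compound 1 to compound 4 (0.46 log units; beyond the scatter).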

Compound 4, half-maximal inhibitory concentration: 66 nM
The estimate for compound 4 lay 2.6-fold (0.42 log units) below the measured number, and the stated range covers the measured number.
By their numbers in this assay, from the lowest: compound 1; then compounds 4 and 2 (each within the scatter of the next); then compound 3.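

In this assay, among these compounds, the only earlier step at this substituent, a 2.4-fold higher number from compound 2 to compound 3 (0.37 log units; beyond the scatter), changed what sat on a carbonyl carbon while the carbonyl itself stayed in place. The new pair goes further and replaces the whole group on the piperidine nitrogen, sulfonyl for carbonyl, giving a 7.7-fold higher number from compound 1 to compound 4 (0.89 log units; beyond the scatter) with the (4-fluorophenyl)amino group unchanged. So 1-(cyclopropylsulfonyl)piperidin-3-yl gives the lower number of the two, yet the exchange does not abolish activity, since compound 4 still gives 66 nM. Nothing available explains this shift.

The exchange alters the sulfonyl link, the cyclopropyl ring and the hydroxymethyl end together, so the compounds shown cannot tell which of these changes carries the step; a methylsulfonyl group or a cyclopropylcarbonyl group on the same ring nitrogen would begin to separate them. Also open, from the compounds shown here alone, is how this position would respond to an amine such as a dimethylaminoacetyl group, or to a carboxylic acid on a longer chain.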